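This account rests on a few compounds, and the source may have more. Where it says the series, first, only, none or still open, it means among the compounds named here.

In an in vitro assay on BTI-TN-5B1-4 cells for inhibition of Amine oxidase [flavin-containing] B (Homo sapiens), read by fluorescence (on this read-out lower numbers stand for stronger inhibition and higher numbers for weaker inhibition), compound 2 `CCc1ccc(NC(=O)c2cc3ccccc3oc2=O)cc1` gives 890 nM, the highest of the two numbers measured, though the nearest, compound 1 `O=C(Nc1ccccc1)c1cc2ccccc2oc1=O`, gives 760 nM, within the scatter of it. That earlier step, a 1.2-fold higher number from compound 1 to compound 2 (0.07 log units; within the scatter), brought ethyl in place of hydrogen on an aromatic carbon. Compound 3 `CC(C)c1ccc(NC(=O)c2cc3ccccc3oc2=O)cc1` differs from compound 2 by methyl in place of hydrogen on a saturated chain carbon bound to an aromatic carbon and a saturated chain carbon. For the measured compounds named here, only that one step bears on the change, and it was small, so no step beyond the scatter is expected in this assay. Compound 3 is therefore estimated at 1000 nM, between 450 nM and 2200 nM, an expected step of a 1.1-fold higher number from compound 2 to compound 3 (0.05 log units; within the scatter).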

Compound 3, half-maximal inhibitory concentration: 650 nM
Compound 3: the middle estimate sits 1.5-fold (0.19 log units) above what was measured; low and high end bracket the measured number.
By their numbers in this assay, from the lowest: compounds 3, 1 and 2 (each within the scatter of the next).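

In this assay the swap of ethyl to isopropyl reads as a 1.4-fold lower number from compound 2 to compound 3 (0.14 log units; within the scatter) and stays within the scatter. The comparison with the unsubstituted compound reads as a 1.2-fold lower number from compound 1 to compound 3 (0.07 log units; within the scatter) and also stays within it, so this position now holds a branched group as well as ethyl and hydrogen with no step beyond the scatter. Nothing available explains why these numbers stay so close.

From the compounds shown here alone, whether an amine, a carboxylic acid or a longer chain at this position would give a step beyond the scatter stays open. So does whether such a step would appear with a methoxy group.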